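Ring substituent variation against protein kinase C delta

The compounds below may be only part of what the source reports. "The series", "measured", "known", "first", "only" and "open" are said of these compounds alone.

Compound 1 `N#Cc1cnc(NCc2cnccc2C(F)(F)F)cc1N[C@H]1C[C@@H](O)C1`: in an assay on isolated protein for inhibition of protein kinase C delta type (Homo sapiens), read by TR-FRET, with a stated time of 2 h (on this read-out lower numbers stand for stronger inhibition and higher numbers for weaker inhibition), compound 1 gives > 10000 nM, a limit of the assay rather than a number.
Compound 2 `CO[C@H]1CC[C@H](Nc2cc(NCc3cnccc3C(F)(F)F)ncc2C#N)CC1`: in this assay compound 2 gives > 10000 nM, again a limit.
Compound 3 `CO[C@H]1CC[C@@H](CNc2cc(NCc3cnccc3C(F)(F)F)ncc2C#N)CC1`: in this assay compound 3 gives 5000 nM.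

For the measured compounds named here, compound 3 holds the only number in the set; the other two values are limits, both sitting at the limit of > 10000 nM in this assay, at which 2 of the 3 values shown sit. The steps of an at least 2.0-fold lower number from compound 1 to compound 3 (0.30 log units; that floor lies within the scatter) and an at least 2.0-fold lower number from compound 2 to compound 3 (0.30 log units; that floor lies within the scatter) therefore carry only a floor, and the step that the two limits leave unreadable from compound 1 to compound 2 cannot be read at all.

Compound 4 `CC1(C)C[C@@H](Nc2cc(NCc3cnccc3C(F)(F)F)ncc2C#N)CC[C@H]1O` differs from compound 3 by 4-hydroxy-3,3-dimethylcyclohexyl in place of (4-methoxycyclohexyl)methyl on a nitrogen on an aromatic ring. Going by the values given here, the step that bears on it is the one from compound 2, where the ring also sits directly on the nitrogen without a methylene, and there the reverse of an at least 2.0-fold lower number from compound 2 to compound 3 (0.30 log units; that floor lies within the scatter) is an increase of unknown size. A rise in the number toward the limit is therefore expected, with a fair chance that only a limit is reported.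

Compound 4 is expected at 8000 nM, within 2500 nM to 25000 nM. The expected step is a 1.6-fold higher number from compound 3 to compound 4 (0.20 log units; within the scatter).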

Compound 4, half-maximal inhibitory concentration: 2400 nM
The estimate for compound 4 lay 3.3-fold (0.52 log units) above the measured number, outside the stated range (below it).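

At the substituent on the nitrogen, a ring set directly on that nitrogen can give a measured number in this assay, so the methylene of compound 3 is not needed for one: the change to 4-hydroxy-3,3-dimethylcyclohexyl gives a 2.1-fold lower number from compound 3 to compound 4 (0.32 log units; beyond the scatter). Within the directly attached rings, the same group gives an at least 4.1-fold lower number from compound 2 to compound 4 (0.61 log units; beyond the scatter) against 4-methoxycyclohexyl and an at least 4.1-fold lower number from compound 1 to compound 4 (0.61 log units; beyond the scatter) against 3-hydroxycyclobutyl. These last two steps give only a floor and not a size: the limit of > 10000 nM in this assay, at which 2 of the 4 values shown sit.

The compounds shown do not separate the hydroxy group from the two methyl groups, since compound 4 differs from compound 2 in both. As far as these compounds go, whether an amine or a carboxylic acid in place of that hydroxy group would keep, lower or raise the number remains open.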